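Ethyl on the aromatic ring of a thiazolidinone series

The compounds below may be only part of what the source reports. "The series", "measured", "known", "first", "only" and "open" are said of these compounds alone.

Compound 2 `O=C(O)CCCSCCN1C(=O)SC[C@@H]1/C=C/[C@@H](O)Cc1ccccc1` is the member with an unsubstituted aromatic ring. In an assay on CHO cells for displacement of a labelled ligand from prostaglandin E2 receptor EP2 subtype (Mus musculus), read by scintillation counting, with a stated time of 60 min (a lower number here means a stronger inhibitor, a higher number a weaker inhibitor), compound 2 gives only a limit, > 10000 nM. Compound 1 `CCc1cccc(C[C@H](O)/C=C/[C@H]2COC(=O)N2CCSCCCC(=O)O)c1` carries ethyl on an aromatic carbon and an oxygen-containing core; in this assay compound 1 also gives only a limit, > 10000 nM. Compound 3 `O=C(O)CCCSCCN1C(=O)OC[C@@H]1/C=C/[C@@H](O)Cc1cccc(-c2ccccc2)c1` carries phenyl in place of that ethyl; in this assay compound 3 gives only a limit as well, > 10000 nM. Among the compounds with values here, the sole step among measured compounds, a step that the two limits leave unreadable from compound 1 to compound 3, is therefore unreadable, since every value sits at the limit of > 10000 nM in this assay, at which 3 of the 3 values shown sit.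

Compound 4 `CCc1cccc(C[C@H](O)/C=C/[C@H]2CSC(=O)N2CCSCCCC(=O)O)c1` differs from compound 2 by ethyl in place of hydrogen on an aromatic carbon. Within the data shown here, no measured step bears readably on this change, and the nearest comparison, compound 1, carries the same ethyl on a related core without yielding a number. Compound 4 is therefore expected to remain at or near the limit, estimated at 15000 nM with a range of 5000 nM to 50000 nM. The expected step that the limit leaves unreadable from compound 2 to compound 4 starts from a limit and is not expected to be readable.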

Compound 4, inhibition constant: > 10000 nM
Compound 4 ended at the assay's limit; the forecaster's own chance of this, stated with the estimate: 85%; the middle value lies beyond the limit too.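

No new step can be read between compound 2 and compound 4, as both give only a limit in this assay: the limit of > 10000 nM in this assay, at which 4 of the 4 values shown sit.

The compounds shown leave open how strongly any of them acts in this assay, and whether ethyl on the aromatic ring changes that at all.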